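The source may hold more compounds than are shown below. What is called first, only, known or untested is meant among the compounds shown, and "the series" means these compounds.

Measured so far in a functional assay on T47D cells (Homo sapiens) for antiproliferative activity, read by sulforhodamine B assay, with a stated time of 48 h; a lower number here means that less compound is tolerated, a higher number that more compound is tolerated:
Compound 1 `COc1ccc(OC)c(/C=C/c2nnc(Nc3ccc(Cl)cc3)o2)c1` gives > 100000 nM; this value is a limit of the assay, not a number.
Compound 2 `COc1ccc(OC)c(/C=C/C(=O)N/N=C/c2ccc(Cl)cc2)c1` gives > 100000 nM; this too is a limit, not a number.

Compound 2 thus stands at the limit of this assay, and compound 1 shares that position (the limit of > 100000 nM in this assay, at which 2 of the 2 values shown sit). Within the data shown here, neither value is a number, so no step between measured compounds can be computed; the two values show only that both compounds sit at the same limit.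

Compound 3 `COc1ccc(OC)c(/C=C/C(=O)N/N=C/c2ccccc2)c1` differs from compound 2 by hydrogen in place of chloro on an aromatic carbon. With both measured values at the limit, no direction for such a change is established in this series. The step of a number no higher from compound 2 to compound 3 (the limit leaves the size open) is expected to be none beyond the scatter. Compound 3 is expected at 100000 nM, with a range of 30000 nM to 300000 nM, and this assay will most likely again report only a limit.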

Compound 3, concentration lethal to 50% of the cells: > 100000 nM
Compound 3: a limit, no number (the forecaster's own chance of this, stated with the estimate: 80%); the middle value lies on the limit itself.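

The step from compound 2 to compound 3, hydrogen in place of chloro, cannot be read in this assay, since both values are limits and not numbers: the limit of > 100000 nM in this assay, at which 3 of the 3 values shown sit.

The compounds shown leave open whether 4-chlorophenyl to phenyl changes anything in this assay, and which structure would give a value off the limit.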